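The source may hold more compounds than are shown below. What is called first, only, known or untested is meant among the compounds shown, and "the series" means these compounds.

Working notes on a small series tested in an assay on CHO cells for binding affinity to prostaglandin E2 receptor EP3 subtype (Mus musculus); on this read-out lower numbers stand for stronger inhibition and higher numbers for weaker inhibition. Compound 2 `CCCCC[C@H](O)/C=C/[C@H]1[C@H](O)CC(=O)[C@@H]1CSCCCCC(=O)O` gives 2 nM in this assay, the lowest of the two numbers in hand. For the measured compounds named here, compound 1 `COCc1cccc(C[C@H](O)/C=C/[C@H]2[C@H](O)CC(=O)[C@@H]2CCSCCCC(=O)O)c1` gives 56 nM in this assay; the two compounds differ in more than one place, so no single step connects them, and the gap between their numbers lies beyond the scatter. Compound 3 `CCCCC[C@H](O)/C=C/[C@H]1[C@H](O)CC(=O)[C@@H]1CCSCCCC(=O)O` has not yet been measured. It differs from compound 2 in one place: ((3-carboxypropyl)sulfanyl)methyl in place of (4-carboxybutyl)sulfanyl on a saturated chain carbon bound to a saturated ring carbon. Going by the values given here, no measured pair shows this change on its own. Compound 1 carries the same ((3-carboxypropyl)sulfanyl)methyl arrangement but differs from compound 3 elsewhere as well, so its number cannot be read as the effect of this change alone. A step towards a higher number is expected, of a size that may or may not exceed the scatter. The expected step is a 4.0-fold higher number from compound 2 to compound 3 (0.60 log units; beyond the scatter). Compound 3 is expected to give 8 nM in this assay, with a range from 2 nM to 40 nM.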

Compound 3, inhibition constant: 1.9 nM
Compound 3: the middle estimate sits 4.2-fold (0.62 log units) above what was measured; the whole stated range lies above it.
By their numbers in this assay, from the lowest: compounds 3 and 2 (each within the scatter of the next); then compound 1.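

In this assay, ((3-carboxypropyl)sulfanyl)methyl in place of (4-carboxybutyl)sulfanyl on a saturated chain carbon bound to a saturated ring carbon gives a 1.1-fold lower number from compound 2 to compound 3 (0.02 log units; within the scatter), so this read-out does not separate the two arrangements of the same atoms. With the ((3-carboxypropyl)sulfanyl)methyl arrangement held constant, butyl in place of 3-(methoxymethyl)phenyl gives a 29-fold lower number from compound 1 to compound 3 (1.47 log units; beyond the scatter), which isolates a large step at that other position, on a saturated chain carbon, two bonds along the chain from a double-bonded chain carbon and an oxygen on a saturated carbon. No supporting data are available to explain either result.

The compounds shown do not tell whether the sulfur-containing chain would keep this insensitivity with an oxygen in place of the sulfur, a longer chain or an amide in place of the carboxylic acid. They also leave open how much of the large step belongs to the phenyl ring and how much to its methoxymethyl group, a question that an unsubstituted phenyl or a benzyl ether at the same position could address.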